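Propylurea in place of methylthiourea on the amine nitrogen

The source may report more compounds than this note shows. Statements on the series, on what has been measured and on what is new or still open speak of the compounds shown alone.

Of the compounds shown here, two carry numbers so far. In an assay for inhibition of Nitric oxide synthase, inducible (Homo sapiens), read by scintillation counting, with a stated time of 30 min, tested at 1 mM (a higher number here means more inhibition at the concentration tested (going by the name of the read-out), a lower number less inhibition), compound 1 `CNC(=S)NCCC(O)c1ccccc1N` gives 20.7%. Compound 2 `CNC(=S)NCCC(O)c1cc(OC)ccc1N` gives 76.6% in this assay, the higher of the two numbers. Going by the values given here, the single measured step, a number 55.9 percentage points higher from compound 1 to compound 2 (beyond the scatter), is all that is known of this assay, and it concerns the aromatic methoxy only.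

Compound 3 `CCCNC(=O)NCCC(O)c1cc(OC)ccc1N` is the next compound to be measured in this assay. The change from compound 2 is a group of 6 heavy atoms (4 carbon, 1 nitrogen, 1 oxygen; no ring) in place of a group of 4 heavy atoms (2 carbon, 1 nitrogen, 1 sulfur; no ring), on an amine nitrogen. Among the compounds with values here, no measured step bears on this part of the molecule: the one step available says nothing about what sits on the amine nitrogen. The direction of the step in this assay is therefore open, and any expectation has to be wide, with its middle set below the number of compound 2 simply as a cautious working guess. Compound 3 is expected to give about 40% in this assay, in a range from 5% to 80%. That guess corresponds to an expected step of a number 36.6 percentage points lower from compound 2 to compound 3 (beyond the scatter).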

Compound 3, a percentage reported as inhibition, at one concentration (the size of the read-out at that concentration, not a potency): 14.7%
Beside the measured number, compound 3's estimate is 25.3 percentage points above it; measured number inside the range.
By their numbers in this assay, from the lowest: compounds 3 and 1 (each within the scatter of the next); then compound 2.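

Going by these compounds alone, the group on the amine nitrogen, which no earlier step touched, carries much of the reading in this assay: with the aromatic methoxy held constant, propylcarbamoyl in place of the group holding sulfur gives a number 61.9 percentage points lower from compound 2 to compound 3 (beyond the scatter) in this series. The high reading of compound 2 at 76.6% therefore depends on more than the methoxy, and it does not survive this exchange on the amine nitrogen. The step bundles two differences, sulfur against oxygen and a methyl against a propyl end, although the hydrogen-bond donor and acceptor counts of the two groups are the same, and no supporting measurement here explains the loss.

The compounds shown do not separate these two differences: a methylurea would isolate the oxygen for sulfur exchange, and a propylthiourea would isolate the longer chain, each on the methoxy-bearing core of compound 2. Also open, on these data alone, is whether a shorter group, such as a bare amine on that nitrogen, or an ethyl end on the sulfur-bearing group would keep the reading of compound 2.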